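The compounds below may be only part of what the source reports. "The series", "measured", "known", "first", "only" and "open" are said of these compounds alone.

Measured so far:
compound 1 `Cc1cc(OCC(=O)N2CCOCC2)cc(C)c1-c1cccc(COc2ccc(OCC(=O)O)c(F)c2)c1` - "not determined" (no result reported)
compound 2 `COc1cc(C)c(-c2cccc(COc3ccc(OCC(=O)O)c(F)c3)c2)c(C)c1` - 3.2

Among the compounds with values here, in a physicochemical assay for lipophilicity, using the shake flask method, in phosphate buffer, measured as octanol-water partition, with a stated time of 24 h, at pH 7.4, tested at 100 uM (on this read-out higher numbers stand for higher lipophilicity and lower numbers for lower lipophilicity), compound 2 gives 3.2 as the only number so far. Within the data shown here, compound 1 has no result, so no comparison is possible and no measured step is available.

Compound 3 `CCCOc1cc(C)c(-c2cccc(COc3ccc(OCC(=O)O)c(F)c3)c2)c(C)c1` differs from compound 2 in one place, with the change ethyl in place of hydrogen on a saturated chain carbon bound to an oxygen on an aromatic ring on a saturated chain carbon bound to an oxygen on an aromatic ring, which turns methoxy into propoxy. Among the measured compounds shown here, with no measured step to go by, the expectation rests on this structural change alone. A step toward a higher number, larger than the usual scatter of this assay on repeat measurement, is expected. For the measured compounds named here, the only anchor is compound 2 at 3.2 with nothing to test the size of the increment. The estimated size is a number 0.80 log units higher from compound 2 to compound 3 (beyond the scatter) and it remains uncertain. For compound 3 the estimate is 4 with a range from 3.5 to 4.5 expected for the measurement.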

Compound 3, distribution coefficient: 3.64
Compound 3: the middle estimate sits 0.36 log units above what was measured; the measured number falls inside the stated range.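

In this assay, the change from methoxy to propoxy gives the series its first readable step, a number 0.44 log units higher from compound 2 to compound 3 (beyond the scatter), so this place on a saturated chain carbon bound to an oxygen on an aromatic ring is one where the read-out moves when ethyl replaces hydrogen. Within the data shown here, the shift is upward and is printed as beyond the scatter, which is more than the single value of compound 2 could show, but it rests on one pair and therefore gives a direction for methoxy to propoxy only, with no rate per added carbon and no rule for other groups at this place. No independent measurement bears on the origin of this step, and the result alone cannot assign one.

Two chain lengths cannot show whether the trend continues with a longer chain such as butoxy or changes with a branched chain such as isopropoxy. On these data alone, it also remains open how the read-out would respond if this place carried a chain bearing an amine or a carboxylic acid, since either would test more than chain length alone.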